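Two oxygens leave a sulfonyl linker in compound 1

The compounds below may be only part of what the source reports. "The series", "measured", "known", "first", "only" and "open" are said of these compounds alone.

Going by the values given here, the three compounds measured so far share one core. In a functional assay on DU-145 cells (Homo sapiens) for inhibition, read by trypan blue exclusion, with a stated time of 96 h (a lower number here means a stronger inhibitor of growth, a higher number a weaker inhibitor of growth), compound 1 `O=C(/C(=C\c1c(O)cc(O)cc1O)S(=O)(=O)c1ccccc1Br)c1ccc(Cl)cc1` gives 50000 nM. Compound 2 `O=C(/C(=C\c1ccc([N+](=O)[O-])c(O)c1)SCc1ccc(Br)cc1)c1c(F)c(F)c(F)c(F)c1F` gives 10000 nM in this assay, so compound 1 holds the higher of the two numbers, the weaker growth inhibitor, and the gap to compound 2 lies beyond the usual scatter. Compound 3 `Cc1ccc(CS(=O)(=O)/C(=C/c2c(O)cc(O)cc2O)C(=O)c2ccc(Cl)cc2)cc1` reaches only the limit of this assay, > 100000 nM, which is a limit and not a number. Among the compounds with values here, the one measured step, an at least 2.0-fold higher number from compound 1 to compound 3 (0.30 log units; that floor lies within the scatter), changes the group on the sulfonyl sulfur, and its floor rests on (the limit of > 100000 nM in this assay, at which 1 of the 3 values shown sits).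

Compound 4 `O=C(/C(=C\c1c(O)cc(O)cc1O)Sc1ccccc1Br)c1ccc(Cl)cc1` differs from compound 1 in another way: (2-bromophenyl)sulfanyl in place of (2-bromophenyl)sulfonyl on a double-bonded chain carbon bound to a carbonyl carbon and a double-bonded chain carbon. Within the data shown here, no measured step touches the sulfonyl oxygens themselves; the step to compound 3 changes only the group attached to the sulfur, and compound 2 differs in several places at once. There is therefore no measured basis for a direction, and the expected change in this assay is none beyond the scatter. The estimate for compound 4 is 50000 nM, with a range from 15000 nM to 150000 nM, which is expected to mean no change at the digits printed from compound 1 to compound 4 (within the scatter).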

Compound 4, concentration for 50% growth inhibition: > 100000 nM
Compound 4: no number, only a limit; the forecaster's own chance of this, stated with the estimate: 25%; middle value at least 2.0-fold (0.30 log units) from the limit.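

The two sulfonyl oxygens can go without any gain in growth inhibition in this assay: compound 4 gives > 100000 nM, which is a limit and not a number. Going by these compounds alone, this is the first measured change to the linker itself rather than to the group carried on the sulfur, and it reads as an at least 2.0-fold higher number from compound 1 to compound 4 (0.30 log units; that floor lies within the scatter), so the true size of the step cannot be read and it offers no sign of a lower number. Neither change to compound 1 at this site, the new group on the sulfonyl sulfur in compound 3 or the sulfanyl linker in compound 4, yields a measurable number, which means that both steps rest on the same ceiling: the limit of > 100000 nM in this assay, at which 2 of the 4 values shown sit.

Still open, going by these compounds, is whether a sulfinyl linker, with a single oxygen on the sulfur, or an amide linker at this position would give a lower number than compound 1 in this assay. Also open, on these data alone, is whether the 2-bromophenyl group matters on the sulfanyl linker, since a sulfanyl compound carrying a benzyl group on the same core would be needed to separate the two effects.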